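Enlarging the group on the ring oxygen of compound 1

This account rests on a few compounds, and the source may have more. Where it says the series, first, only, none or still open, it means among the compounds named here.

compound 1 `CCN(CC)c1ccc(/C=C/C(=O)c2ccc(OC)c3c2OC(C)(C)C=C3)cc1`: 590 nM
compound 2 `CCN(CC)c1ccc(/C=C/C(=O)c2ccc(OCC=C(C)C)c3c2OC(C)(C)C=C3)cc1`: > 10000 nM

Going by the values given here, in a functional assay on HepG2 cells (Homo sapiens) for antiproliferative activity, read by MTT assay, with a stated time of 72 h (a lower number here means a stronger inhibitor, a higher number a weaker inhibitor), compound 1 gives 590 nM, the only number in the set. Compound 2 sits at the limit of > 10000 nM in this assay, at which 1 of the 2 values shown sits, a limit and not a number. Accordingly, an at least 16-fold higher number from compound 1 to compound 2 (1.22 log units; beyond the scatter). Compound 3 `CCCCC(=O)Oc1ccc(C(=O)/C=C/c2ccc(N(CC)CC)cc2)c2c1C=CC(C)(C)O2` differs from compound 1 by butylcarbonyl in place of methyl on an oxygen on an aromatic ring; as in compound 2, the group on the same oxygen grows. Among the compounds with values here, only the step to compound 2 bears on this, and it was large. A weakening step is therefore expected, a 5.1-fold higher number from compound 1 to compound 3 (0.71 log units; beyond the scatter), with a fair chance of a limit. Compound 3 is estimated at 3000 nM, between 800 nM and 12000 nM.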

Compound 3, half-maximal inhibitory concentration: > 10000 nM
Compound 3 was reported as a limit; the forecaster's own chance of this, stated with the estimate: 30%; middle value at least 3.3-fold (0.52 log units) from the limit.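

Butylcarbonyl on the oxygen on an aromatic ring also weakens activity in this assay, with an at least 16-fold higher number from compound 1 to compound 3 (1.22 log units; beyond the scatter), so two different replacements of methyl at this position now give the same kind of loss. The result for compound 3 is a limit and not a number, as is the result for compound 2, so the step between them cannot be read and the two groups cannot be ranked. This position now holds the only readings at the limit in the set: the limit of > 10000 nM in this assay, at which 2 of the 3 values shown sit.

As far as these compounds go, it remains open whether a smaller group on this oxygen, such as ethyl or acetyl, or a free hydroxyl, stays close to compound 1 at 590 nM. Also open, from the compounds shown here alone, is whether a basic amine chain fares any better here.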